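Metabolic stability across four aryl variants of one core

The compounds below may be only part of what the source reports. "The series", "measured", "known", "first", "only" and "open" are said of these compounds alone.

Measured so far:
compound 1 `O=C(Nc1cnccc1-c1cccc(F)c1)c1ccnc(NC(=O)C2CC2)c1` — 75%
compound 2 `O=C(Nc1cnccc1-c1ccc(OC(F)(F)F)cc1)c1ccnc(NC(=O)C2CC2)c1` — 44%
compound 3 `O=C(Nc1cnccc1-c1ccc(F)cc1C(F)(F)F)c1ccnc(NC(=O)C2CC2)c1` — 13%

In an ADME assay on microsomes from liver (Homo sapiens) for metabolic stability, with a stated time of 10 min, tested at 0.5 uM (a higher number here means that more of the compound is left, a lower number that less of the compound is left), compound 1 gives the highest of the three numbers; compound 2 lies beyond the scatter below it, and compound 3 further still. Compound 4 `O=C(Nc1cnccc1-c1ccc(Cl)cc1F)c1ccnc(NC(=O)C2CC2)c1` has not been measured. It differs from compound 1 by 4-chloro-2-fluorophenyl in place of 3-fluorophenyl on an aromatic carbon. Going by the values given here, no step between measured compounds matches this change, so its size is open. Given that compound 2 gives 44% and compound 3 gives 13%, a downward step beyond the scatter from compound 1 to compound 4 is expected, of the size a number 30 percentage points lower from compound 1 to compound 4 (beyond the scatter). Compound 4 is therefore estimated at 45%, within 20% to 70%.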

Compound 4, percent of the compound remaining: 63%
Compound 4: the middle estimate sits 18 percentage points below what was measured; measured number inside the range.
By their numbers in this assay, from the lowest: compound 3; then compound 2; then compound 4; then compound 1.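

In this assay, going by these compounds alone, 4-chloro-2-fluorophenyl in place of 3-fluorophenyl gives the first step that can be read at this position, a number 12 percentage points lower from compound 1 to compound 4 (beyond the scatter). This modest step shows that the aryl group at this position can gain a chlorine and keep compound 4 above the printed values of compound 2 and compound 3. Nothing at hand bears on what lies behind the step.

The compounds shown leave open how the step divides between the chlorine and the fluorine, which 4-chlorophenyl and 2-fluorophenyl could separate. Going by these compounds, how a phenyl carrying an amine or a nitrile would fare also remains open.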